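Trimming a sulfonamide substituent in an anticancer series

This account rests on a few compounds, and the source may have more. Where it says the series, first, only, none or still open, it means among the compounds named here.

Compound 1 `Cc1ccc(C(/C=C/c2ccc(F)cc2)=N\Nc2nncc3ccccc23)cc1`: 4.5 nM
Compound 2 `O=C1CS/C(=N/Nc2nncc3ccccc23)N1c1ccccc1`: 44 nM
Compound 3 `Cc1cc(NS(=O)(=O)c2ccc(Nc3nncc4ccccc34)cc2)no1`: 54 nM

All three compounds share a core and were tested in a functional assay on OVCAR-3 cells (Homo sapiens) for antiproliferative activity, read by sulforhodamine B assay, with a stated time of 72 h; a lower number here means a stronger inhibitor, a higher number a weaker inhibitor. Compound 1 gives the lowest number of the three, 4.5 nM. Compound 2 gives 44 nM, and compound 3 gives 54 nM, the highest of the three numbers. Compound 3 sits close to compound 2, within the scatter of repeated measurements, but it is well separated from compound 1, whose number is lower by a gap beyond the scatter.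

Compound 4 `NS(=O)(=O)c1ccc(Nc2nncc3ccccc23)cc1` has not yet been measured in this assay. It differs from compound 3 in one place: hydrogen in place of 5-methyl-1,2-oxazol-3-yl on a sulfonamide nitrogen. Within the data shown here, no pair of measured compounds shows this kind of change, so there is no measured step to lean on; the expectation rests on compound 3 alone.

Given that compound 3 gives 54 nM, compound 4 is expected to land at a somewhat higher number, with the step of a 1.9-fold higher number from compound 3 to compound 4 (0.27 log units; within the scatter) estimated to be small, close to the edge of the usual scatter. The estimate for compound 4 is 100 nM, with a range from 30 nM to 350 nM.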

Compound 4, half-maximal inhibitory concentration: 14 nM
Compound 4: the middle estimate sits 7.1-fold (0.85 log units) above what was measured; the whole stated range lies above it.
By their numbers in this assay, from the lowest: compound 1; then compound 4; then compounds 2 and 3 (each within the scatter of the next).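

In this assay, among these compounds, replacing the 5-methyl-1,2-oxazol-3-yl group on the sulfonamide nitrogen with hydrogen gives a 3.9-fold lower number from compound 3 to compound 4 (0.59 log units; beyond the scatter), a modest step but one beyond the scatter, and the first change in this set that can be read at a single place. The result shows that this five-membered aromatic ring is not required for activity in these cells, since the plain sulfonamide, which carries only hydrogen on that nitrogen, gives the lower number. Nothing available here bears on why the number falls when the ring is removed, so the step stands as an observation without an explanation.

From the compounds shown here alone, the two compounds show only the extremes of this change, a whole ring and a single hydrogen, so it remains open how a small group such as methyl or acetyl on the same nitrogen would read in this assay. Going by these compounds, one step also cannot establish a trend, and it remains open whether removing a ring from this nitrogen would give a similar step with a different ring, such as pyridine or thiazole, in place of the 5-methyl-1,2-oxazol-3-yl group.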